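This account rests on a few compounds, and the source may have more. Where it says the series, first, only, none or still open, it means among the compounds named here.

Measured so far in a functional assay on MCF7 cells (Homo sapiens) for antiproliferative activity, read by MTT assay, with a stated time of 48 h; on this read-out higher numbers stand for weaker inhibition and lower numbers for stronger inhibition:
compound 1 `CN(C)CCNc1cc2c(cn1)cc(NC(=O)c1ccc(N)cc1)c(=O)n2C`: 55800 nM
compound 2 `CN(C)CCNc1cc2c(cn1)cc(NC(=O)c1ccc(Cl)cc1)c(=O)n2C`: 3090 nM
compound 3 `COc1ccc(C(=O)Nc2cc3cnc(NCCN(C)C)cc3n(C)c2=O)cc1`: 37300 nM

Compound 3 sits level with compound 1, as a 1.5-fold lower number from compound 1 to compound 3 (0.17 log units; within the scatter) shows. Both stand well clear of compound 2, as seen in an 18-fold lower number from compound 1 to compound 2 (1.26 log units; beyond the scatter) and a 12-fold higher number from compound 2 to compound 3 (1.08 log units; beyond the scatter).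

The next compound is compound 4 `CN(C)CCNc1cc2c(cn1)cc(NC(=O)c1ccncc1)c(=O)n2C`, with this change: pyridin-4-yl in place of 4-methoxyphenyl on a carbonyl carbon. In words, pyridin-4-yl replaces 4-methoxyphenyl on a carbonyl carbon.

Among the measured compounds shown here, none of the measured steps replaces a whole ring. Each swaps one substituent on an aromatic carbon, so they bear on this change only indirectly. Only the chloro group of compound 2 gives a large step, while the amino and methoxy compounds do not separate. Compound 4 carries no chloro group, so in this assay it is expected to stay with compound 1 and compound 3, with no step beyond the scatter.

The estimated step is a 1.2-fold lower number from compound 3 to compound 4 (0.09 log units; within the scatter).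

For compound 4 the estimated value is 30000 nM, with an expected range of 9000 nM to 100000 nM.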

Compound 4, half-maximal inhibitory concentration: 36600 nM
For compound 4 the middle estimate is 1.2-fold (0.09 log units) below the measured one, and the stated range covers the measured number.
By their numbers in this assay, from the lowest: compound 2; then compounds 4, 3 and 1 (each within the scatter of the next).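

In this assay, the whole group on the carbonyl carbon can change from 4-methoxyphenyl to pyridin-4-yl, a ring with a hetero atom and no substituent, without the numbers separating (a 1.0-fold lower number from compound 3 to compound 4 (0.01 log units; within the scatter)), and the same holds against the 4-aminophenyl amide (a 1.5-fold lower number from compound 1 to compound 4 (0.18 log units; within the scatter)). The 4-chlorophenyl amide remains the only one of the four standing apart, and the pyridin-4-yl amide lies well off it (a 12-fold higher number from compound 2 to compound 4 (1.07 log units; beyond the scatter)). No measurement at hand accounts for that gap.

On these data alone, whether the gap belongs to chloro alone, or would also appear with bromo or trifluoromethyl on the same aromatic carbon, stays open. Also open, as far as these compounds go, is whether pyridin-3-yl or plain phenyl on the carbonyl carbon would stay with compound 1, compound 3 and compound 4.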